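Sulfur substituent series: cytotoxicity on Vero cells

The source may report more compounds than this note shows. Statements on the series, on what has been measured and on what is new or still open speak of the compounds shown alone.

Measured so far:
Compound 1 `COc1ccc(-c2nn3c(SC)cc(NC4CCCC4)cc3c2-c2ccnc(NC3CCCC3)n2)cc1` gives > 40000 nM in an ADME assay on Vero cells (Chlorocebus sabaeus) for cytotoxicity; a lower number here means that less compound is tolerated, a higher number that more compound is tolerated.
Compound 2 `CCSc1cc(NC2CCCC2)cc2c(-c3ccnc(NC4CCCC4)n3)c(-c3ccc(OC)cc3)nn12` gives > 40000 nM in this assay.
Compound 3 `COc1ccc(-c2nn3c(SC(C)C)cc(NC4CCCC4)cc3c2-c2ccnc(NC3CCCC3)n2)cc1` gives > 40000 nM in this assay.

Each of these values is a limit of the assay rather than a number. Compound 3 therefore stands at the limit, and the steps a step that the two limits leave unreadable from compound 1 to compound 2, a step that the two limits leave unreadable from compound 1 to compound 3 and a step that the two limits leave unreadable from compound 2 to compound 3 cannot be read in either direction or size.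

Compound 4 `COc1ccc(-c2nn3c(Sc4ccccc4)cc(NC4CCCC4)cc3c2-c2ccnc(NC3CCCC3)n2)cc1` differs from compound 3 by phenyl in place of isopropyl on a sulfur. Among the compounds with values here, no measured step bears readably on this change; the only guide is the limit of > 40000 nM in this assay, at which 3 of the 3 values shown sit, so a value at or near the limit is expected. Compound 4 is expected at 40000 nM, with a range from 15000 nM to 100000 nM. The step expected in this assay is a number no higher from compound 3 to compound 4 (the limit leaves the size open), most likely again reported only as a limit.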

Compound 4, half-maximal cytotoxic concentration: > 40000 nM
Compound 4: no number, only a limit; the forecaster's own chance of this, stated with the estimate: 70%; the middle value lies on the limit itself.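

In this assay compound 4 gives > 40000 nM, again a limit. Within the data shown here, no step among compound 1, compound 2, compound 3 and compound 4 can be read: the limit of > 40000 nM in this assay, at which 4 of the 4 values shown sit. The compounds shown leave open how the four sulfur substituents rank in cytotoxicity, and whether any sulfur substituent gives a readable number.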